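A few compounds are considered here, and "the series" means these few. Any claim that something is new, unique, unknown or untested is made for them only; others in the source may bear on it.

Of the compounds shown here, three that share one core have been measured in a functional assay on DU-145 cells (Homo sapiens) for inhibition, read by trypan blue exclusion, with a stated time of 72 h; on this read-out lower numbers stand for stronger inhibition and higher numbers for weaker inhibition. Compound 1 `Cn1c(=O)c(S(=O)(=O)Cc2ccc(F)cc2F)cc2cnc(Nc3ccc4[nH]ccc4c3)nc21` gives 1000 nM in this assay. Compound 2 `Cc1ccc(S(=O)(=O)c2cc3cnc(Nc4ccc5[nH]ccc5c4)nc3n(C)c2=O)cc1` gives 750 nM in this assay. Compound 3 `Cn1c(=O)c(S(=O)(=O)c2ccc(N)cc2F)cc2cnc(Nc3ccc4[nH]ccc4c3)nc21` gives 8000 nM in this assay. Compound 2 shows the lowest of the three numbers, yet its step to compound 1, a 1.3-fold lower number from compound 1 to compound 2 (0.12 log units; within the scatter), lies within the scatter, so the two are not told apart; only compound 3 stands clearly apart, through an 8.0-fold higher number from compound 1 to compound 3 (0.90 log units; beyond the scatter) and an 11-fold higher number from compound 2 to compound 3 (1.03 log units; beyond the scatter).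

Compound 4 `Cc1ccc(S(=O)(=O)c2cc3cnc(Nc4cccc5[nH]ccc45)nc3n(C)c2=O)cc1` has not yet been measured. It differs from compound 2 in one place: 1H-indol-4-yl in place of 1H-indol-5-yl on a nitrogen on an aromatic ring. All three measured steps exchanged the group on the sulfonyl sulfur and left the (1H-indol-5-yl)amino untouched, so none of them bears directly on this change; their sizes show only that one part of the molecule accepts some exchanges and not others. Within the data shown here, with no step that speaks to the indolyl, the expectation can only be loose. Compound 4 is expected to land near compound 2, with an estimated step of a 2.0-fold higher number from compound 2 to compound 4 (0.30 log units; within the scatter) and a wide range around it. The estimate for compound 4 in this assay is 1500 nM, between 400 nM and 6000 nM.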

Compound 4, half-maximal inhibitory concentration: 10000 nM
Compound 4: the middle estimate sits 6.7-fold (0.82 log units) below what was measured, outside the stated range (above it).
By their numbers in this assay, from the lowest: compounds 2 and 1 (each within the scatter of the next); then compounds 3 and 4 (each within the scatter of the next).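

Moving the attachment point on the indole, while keeping the same atoms and the same counts of donors and acceptors, gives a 13-fold higher number from compound 2 to compound 4 (1.12 log units; beyond the scatter) in this assay. Among these compounds, the earlier steps all exchanged the group on the sulfonyl sulfur and left the (1H-indol-5-yl)amino untouched, so this is the first view of the other end of the molecule, and it shows that this position responds strongly to where the indole is joined to the nitrogen, not merely to which atoms are present. Nothing available explains why this shift in the point of attachment matters so much.

As far as these compounds go, with only the 1H-indol-5-yl and 1H-indol-4-yl groups compared, and only with 4-methylphenyl on the sulfonyl sulfur, it remains open whether the same loss would appear alongside a different sulfonyl group such as 2,4-difluorobenzyl. Also open, from the compounds shown here alone, is how other groups on this nitrogen would fare, such as 1H-indol-6-yl, or 1-methyl-1H-indol-5-yl, which would show whether the indole's ring hydrogen on nitrogen matters here.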